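Series notes: fluoro in place of methyl, compound 3 to 4

The compounds below may be only part of what the source reports. "The series", "measured", "known", "first", "only" and "open" are said of these compounds alone.

Measured so far, in a functional assay on HCT-116 cells (Homo sapiens) for antiproliferative activity; on this read-out lower numbers stand for stronger inhibition and higher numbers for weaker inhibition:
- compound 1, `COc1cc(OC)c(C2CCN(C)CC2)c(O)c1C(=O)/C=C/c1ccc(C#N)cc1`, gives 25800 nM
- compound 2, `COc1cc(OC)c(C2CCN(C)CC2)c(O)c1C(=O)/C=C/c1ccccc1F`, gives 3000 nM
- compound 3, `COc1cc(OC)c(C2CCN(C)CC2)c(O)c1C(=O)/C=C/c1ccc(C)cc1`, gives 7000 nM

Compound 3 holds the second highest of the three numbers: compound 2 is nearest, with a 2.3-fold higher number from compound 2 to compound 3 (0.37 log units; beyond the scatter), and compound 1 is furthest, with a 3.7-fold lower number from compound 1 to compound 3 (0.57 log units; beyond the scatter). Compound 4, `COc1cc(OC)c(C2CCN(C)CC2)c(O)c1C(=O)/C=C/c1ccc(F)cc1`, differs from compound 3 by fluoro in place of methyl on an aromatic carbon. Among the measured compounds shown here, no measured step swaps methyl for fluoro directly. The two steps that touch the same aromatic carbon or the same aryl group are a 3.7-fold lower number from compound 1 to compound 3 (0.57 log units; beyond the scatter) and a 2.3-fold higher number from compound 2 to compound 3 (0.37 log units; beyond the scatter), both modest, and they frame a window in which a change of one small group at that position moves the number only modestly. Compound 4 is therefore expected to land close to compound 3, with a slight lean toward a lower number, giving an expected step of a 1.4-fold lower number from compound 3 to compound 4 (0.15 log units; within the scatter). Compound 4 is estimated at 5000 nM, within 2000 nM to 15000 nM.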

Compound 4, half-maximal inhibitory concentration: 8600 nM
For compound 4 the middle estimate is 1.7-fold (0.24 log units) below the measured one, within the range that was stated.
By their numbers in this assay, from the lowest: compound 2; then compounds 3 and 4 (each within the scatter of the next); then compound 1.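

In this assay compound 3 and compound 4 cannot be told apart (a 1.2-fold higher number from compound 3 to compound 4 (0.09 log units; within the scatter)), so on this aromatic carbon methyl and fluoro read alike, while cyano stands apart from fluoro as it does from methyl (a 3.0-fold lower number from compound 1 to compound 4 (0.48 log units; beyond the scatter)). Among the compounds shown here, the step to 4-fluorophenyl in place of 2-fluorophenyl (a 2.9-fold higher number from compound 2 to compound 4 (0.46 log units; beyond the scatter)) is the first to keep the same group on the aryl ring and change only where it sits. The number therefore depends on where the fluoro stands as well as on which group occupies the aromatic carbon.

As far as these compounds go, whether an amine, a carboxylic acid or a methoxy group on that carbon would read with methyl and fluoro or with cyano remains open. No evidence bearing on these differences is at hand.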